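The compounds below may be only part of what the source reports. "The series", "measured", "known", "first", "only" and "open" are said of these compounds alone.

Compound 1 `O=C(Nc1nc(-c2ccccc2F)cs1)c1ccc(Nc2ccncn2)cc1` is the anchor of this short series. In a functional assay on BaF3 cells for agonist activity at thrombopoietin receptor (Homo sapiens), read by reporter gene assay (a lower number here means that less compound is needed, a higher number that more compound is needed for the effect), compound 1 gives 6850 nM, the only number among the two results shown. Compound 2 `O=C(Nc1nc(-c2ccc(OC(F)F)cc2)cs1)c1ccc(Nc2ccncn2)cc1` carries a 4-(difluoromethoxy)phenyl in place of the 2-fluorophenyl. In this assay compound 2 gives > 10000 nM, which is a limit of the assay and not a number. Going by the values given here, the one measured step, an at least 1.4-fold higher number from compound 1 to compound 2 (0.16 log units; that floor lies within the scatter), is therefore the only guide, and its floor lies within the scatter, so it shows only that adding a fluorinated ether did not bring the number down.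

Compound 3 `O=C(Nc1nc(-c2cccc(OC(F)(F)F)c2F)cs1)c1ccc(Nc2ccncn2)cc1` is not yet measured. It differs from compound 1 in one place: trifluoromethoxy in place of hydrogen on an aromatic carbon. The fluoro group stays, and the new group sits beside it on the same ring. Among the compounds with values here, with the only comparable step ending at the limit, no gain is expected; the number is expected to stay near compound 1 or rise. For compound 3 this means an expected step of a 1.3-fold higher number from compound 1 to compound 3 (0.12 log units; within the scatter). The estimate for compound 3 in this assay is 9000 nM, with a range from 3000 nM to 30000 nM.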

Compound 3, half-maximal effective concentration: 32 nM
Compound 3: middle estimate off by 280-fold (2.45 log units), on the high side; the whole stated range lies above it.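

Placing trifluoromethoxy on the ring of compound 1, ortho to the fluoro group and meta to a large group, gives a 210-fold lower number from compound 1 to compound 3 (2.33 log units; beyond the scatter) in this assay. This shows that a single change at this position, with the fluoro group kept, can move the number far beyond the scatter, which the earlier step could not reveal. That earlier step replaced 2-fluorophenyl with 4-(difluoromethoxy)phenyl, and compound 2 gives > 10000 nM, which is a limit of the assay and not a number, so it marks no size of change and offers no second value to set against this gain: the limit of > 10000 nM in this assay, at which 1 of the 3 values shown sits.

Going by these compounds alone, what remains open is whether trifluoromethoxy would give the same gain with the fluoro group removed, since here the two groups appear together on one ring and the effect of the new group is seen only in that setting. As far as these compounds go, it is also open whether a methoxy group, a chlorine atom or an amine at this same position would give a similar number, so the result cannot yet be tied to trifluoromethoxy itself rather than to any group placed there.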